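Quinolinyl for naphthyl on the sulfonyl of compound 3

The source may report more compounds than this note shows. Statements on the series, on what has been measured and on what is new or still open speak of the compounds shown alone.

Measured compounds:
compound 1, `O=S(=O)(c1c(Cl)cccc1Cl)N1CCOc2c(N3CCNCC3)cccc21`, 0.0631 nM
compound 2, `O=S(=O)(c1cccc(F)c1)N1CCOc2c(N3CCNCC3)cccc21`, 10 nM
compound 3, `O=S(=O)(c1cccc2ccccc12)N1CCOc2c(N3CCNCC3)cc(Cl)cc21`, 0.794 nM

Of the compounds shown here, three sharing one core have been measured in an assay on HEK293 cells for displacement of a labelled ligand from 5-hydroxytryptamine receptor 6 (Homo sapiens); on this read-out lower numbers stand for stronger inhibition and higher numbers for weaker inhibition. Compound 1 gives 0.0631 nM, compound 2 gives 10 nM, and compound 3 gives 0.794 nM. Within the data shown here, the only single-point step among them is a 160-fold higher number from compound 1 to compound 2 (2.20 log units; beyond the scatter). Compound 3 stands second highest of the three numbers: its value is a beyond-scatter step above that of compound 1 and the same distance below that of compound 2.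

Compound 4, `O=S(=O)(c1cccc2cccnc12)N1CCOc2c(N3CCNCC3)cc(Cl)cc21`, has not yet been measured. It differs from compound 3 in one place: quinolin-8-yl in place of naphthalen-1-yl on a sulfonyl sulfur. Among the measured compounds shown here, the only measured step that bears on this change is the large one from compound 1 to compound 2, also a swap of the aryl group on the sulfonyl sulfur; yet that swap exchanged far more than one ring atom, whereas the change from compound 3 to compound 4 keeps the same bicyclic shape and adds a single hydrogen-bond acceptor. The expected step is therefore modest, a 1.9-fold higher number from compound 3 to compound 4 (0.28 log units; within the scatter), possibly within the scatter, with a slight lean toward a higher number. Compound 4 is estimated at 1.5 nM, in a range from 0.4 nM to 6 nM in this assay.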

Compound 4, inhibition constant: 0.631 nM
Estimate against measurement, compound 4: 2.4-fold (0.38 log units) above, within the range that was stated.
By their numbers in this assay, from the lowest: compound 1; then compounds 4 and 3 (each within the scatter of the next); then compound 2.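

In this assay, quinolin-8-yl in place of naphthalen-1-yl on the sulfonyl sulfur gives a 1.3-fold lower number from compound 3 to compound 4 (0.10 log units; within the scatter), so the added ring nitrogen, counted as a hydrogen-bond acceptor, leaves the two compounds indistinguishable on this read-out. Until now, this place was known only through a 160-fold higher number from compound 1 to compound 2 (2.20 log units; beyond the scatter), which showed that an exchange of aryl groups on the sulfonyl sulfur can carry a step well beyond the scatter, whereas this exchange, with the same count of heavy atoms, does not. Nothing available here explains why the two exchanges differ so much in size.

The compounds shown leave open whether an isoquinolin-5-yl or a pyridin-3-yl on the same sulfonyl sulfur would also stay within the scatter of compound 3, and whether an amine or a methoxy group added to the quinolin-8-yl would shift the number. They also do not separate the effect of the chlorine on the shared core of compound 3 from that of its sulfonyl aryl group, so the steps that would show this cannot be read.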